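Reversing the enone linker on a weakly antiproliferative core

The compounds below may be only part of what the source reports. "The series", "measured", "known", "first", "only" and "open" are said of these compounds alone.

Compound 1 `COc1cc(-c2cc(C(=O)/C=C/c3ccc(Cl)cc3)nc3cc(-c4ccccc4)nn23)cc(OC)c1OC`: 53900 nM
Compound 2 `COc1ccc(-c2cc(C(=O)/C=C/c3ccc(Cl)cc3)nc3cc(-c4ccccc4)nn23)cc1OC`: 39100 nM
Compound 3 `COc1ccc(C(=O)/C=C/c2cc(-c3ccc(OC)c(OC)c3)n3nc(-c4ccccc4)cc3n2)cc1OC`: 32500 nM

Three compounds built on a shared core were measured in an ADME assay on HEK293 cells (Homo sapiens) for antiproliferative activity, read by MTT assay, with a stated time of 24 h; on this read-out lower numbers stand for stronger inhibition and higher numbers for weaker inhibition. Compound 1 gives 53900 nM, the highest of the three numbers; its nearest neighbour is compound 2, which gives 39100 nM, and the furthest is compound 3, which gives 32500 nM. All three lie within the scatter of one another, so no order can be read among them. Going by the values given here, the single one-place step, a 1.4-fold lower number from compound 1 to compound 2 (0.14 log units; within the scatter), likewise stays inside the scatter.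

Compound 4 `COc1cc(-c2cc(/C=C/C(=O)c3ccc(Cl)cc3)nc3cc(-c4ccccc4)nn23)cc(OC)c1OC` is not yet measured. It differs from compound 1 only in how the same atoms are joined: 2-((4-chlorophenyl)carbonyl)ethenyl in place of (2-(4-chlorophenyl)ethenyl)carbonyl on an aromatic carbon

Among the compounds with values here, no measured step touches this kind of change. Compound 3 carries a carbonyl-and-ethenyl arrangement of the other sense, but it also differs from compound 2 elsewhere, so its value can only be said to sit in the same range as the rest. Within the data shown here, the one step available, a 1.4-fold lower number from compound 1 to compound 2 (0.14 log units; within the scatter), was within the scatter, and nothing here suggests the core tolerates one arrangement of the linker differently from the other. The expectation for compound 4 in this assay is therefore a step of a 1.2-fold lower number from compound 1 to compound 4 (0.08 log units; within the scatter), with no direction beyond the scatter. Compound 4 is estimated at 45000 nM, expected to fall between 20000 nM and 110000 nM.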

Compound 4, half-maximal inhibitory concentration: >= 100000 nM
Compound 4 gave a limit, no number; the forecaster's own chance of this, stated with the estimate: 10%; middle value at least 2.2-fold (0.34 log units) away from the limit.
By their numbers in this assay, from the lowest: compounds 3, 2 and 1 (each within the scatter of the next). At a limit, above all of these: compound 4.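

In this assay compound 4 gives only a limit and not a number, >= 100000 nM. The change on this aromatic carbon of the shared core, 2-((4-chlorophenyl)carbonyl)ethenyl in place of (2-(4-chlorophenyl)ethenyl)carbonyl, is read as an at least 1.8-fold higher number from compound 1 to compound 4 (0.26 log units; that floor lies within the scatter), so the same atoms joined the other way round give no lower number, although only a floor on the step is known and its true size remains undefined. The one earlier one-place step concerned a methoxy group elsewhere on the molecule, so this is the first reading at this position, and it marks compound 4 as the only one of the set that reaches the end of the measurable range: the limit of >= 100000 nM in this assay, at which 1 of the 4 values shown sits.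

The compounds shown leave open how far beyond that limit compound 4 lies, and whether the same reversal of the linker would read alike on the core of compound 2, which lacks one methoxy group. They also leave open what an amine or a carboxylic acid in place of the chlorine on the 4-chlorophenyl ring would do with either sense of the linker.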